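The source may hold more compounds than are shown below. What is called first, only, known or untested is meant among the compounds shown, and "the series" means these compounds.

In an ADME assay on HEK293 cells (Homo sapiens) for cytotoxicity, read by MTT assay, with a stated time of 48 h (on this read-out higher numbers stand for weaker inhibition and lower numbers for stronger inhibition), three compounds built on a shared core have been measured so far. Compound 1 `CN1CCN(CCn2c(N)c(-c3nc4ccccc4[nH]3)c3nc(C#N)c(C#N)nc32)CC1` gives 10900 nM, and compound 3 `CN(C)CCCn1c(N)c(-c2nc3ccccc3[nH]2)c2nc(C#N)c(C#N)nc21` gives 8360 nM. For the measured compounds named here, these two values lie within the usual scatter of each other, so compound 3 stands together with compound 1 as the only compounds with an exact number here. Compound 2 `N#Cc1nc2c(-c3nc4ccccc4[nH]3)c(N)n(CCO)c2nc1C#N` is reported only as a limit, > 50000 nM.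

Compound 4 `CCN(CC)CCCn1c(N)c(-c2nc3ccccc3[nH]2)c2nc(C#N)c(C#N)nc21` has not yet been measured. It has diethylamino in place of the dimethylamino of compound 3, on a saturated chain carbon, three bonds along the chain from an aromatic nitrogen (diethylamino in place of dimethylamino on a saturated chain carbon, three bonds along the chain from an aromatic nitrogen).

Going by the values given here, no measured step makes this exact change, but three steps offer guidance. Exchanging one amino end group for another gave only a 1.3-fold lower number from compound 1 to compound 3 (0.12 log units; within the scatter). The clear moves involve the hydroxy of compound 2, with an at least 4.5-fold higher number from compound 1 to compound 2 (0.66 log units; beyond the scatter) and an at least 5.9-fold lower number from compound 2 to compound 3 (0.77 log units; beyond the scatter). Compound 4 has no hydroxy and keeps an amino end group, so the closest guide is the small step between compound 1 and compound 3. The expected change is a 1.1-fold lower number from compound 3 to compound 4 (0.05 log units; within the scatter), which is no step beyond the scatter. For compound 4 the estimated value is 7500 nM, with an expected range from 3500 nM to 16000 nM.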

Compound 4, half-maximal inhibitory concentration: 7870 nM
For compound 4 the middle estimate is 1.0-fold (0.02 log units) below the measured one; low and high end bracket the measured number.
By their numbers in this assay, from the lowest: compounds 4, 3 and 1 (each within the scatter of the next). At a limit, above all of these: compound 2.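

In this assay, putting diethylamino in place of dimethylamino, on a saturated chain carbon three bonds along the chain from an aromatic nitrogen, gives a 1.1-fold lower number from compound 3 to compound 4 (0.03 log units; within the scatter), so the larger of these two open-chain amines reads the same as the smaller one at this position. The step to the 4-methylpiperazin-1-yl group gives a 1.4-fold lower number from compound 1 to compound 4 (0.14 log units; within the scatter), which means that this ring-bearing amine also reads the same as the new compound, and the group of amine-ended compounds now holds three members with no separation among them. Replacing hydroxy with (diethylamino)methyl gives an at least 6.3-fold lower number from compound 2 to compound 4 (0.80 log units; beyond the scatter), a second clear gap between the hydroxy end group and an open-chain amine, though its starting point is a limit and not a number: the limit of > 50000 nM in this assay, at which 1 of the 4 values shown sits.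

What the compounds shown leave open is whether a different end group on the 3-carbon propyl chain, such as morpholine, piperidine or a carboxylic acid, would stay with the amines or read closer to the hydroxy compound. They also leave open how diethylamino would read on a shorter ethyl chain or on a longer butyl chain.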